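Bromoacyl anilide ureas: methyl removal on the haloacyl chain

A few compounds are considered here, and "the series" means these few. Any claim that something is new, unique, unknown or untested is made for them only; others in the source may bear on it.

Measured so far:
compound 1 `CC(Br)C(=O)Nc1ccc(Br)c(C(=O)NC(N)=O)c1`, 7630 nM
compound 2 `NC(=O)NC(=O)c1cc(NC(=O)CBr)ccc1Br`, 1160 nM
compound 3 `CC(Br)C(=O)Nc1cc(C(=O)NC(N)=O)cs1`, 3940 nM

All values come from a functional assay on CCRF-CEM cells (Homo sapiens) for antiproliferative activity, read by trypan blue exclusion, with a stated time of 72 h; a higher number here means a weaker inhibitor, a lower number a stronger inhibitor. Compound 1 and compound 2 share one core and differ by the change (hydrogen in place of methyl on a saturated chain carbon bound to a bromine atom and a carbonyl carbon); that change gave a 6.6-fold lower number from compound 1 to compound 2 (0.82 log units; beyond the scatter). Compound 3 sits on a different core; the difference between the two cores is not broken down here. In this assay compound 3 gives 3940 nM, near compound 1 and beyond the scatter away from compound 2.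

Compound 4 `NC(=O)NC(=O)c1csc(NC(=O)CBr)c1` is not yet measured. It differs from compound 3 by hydrogen in place of methyl on a saturated chain carbon bound to a bromine atom and a carbonyl carbon, the same change as from compound 1 to compound 2. For the measured compounds named here, the expectation for compound 4 is a step of a 5.6-fold lower number from compound 3 to compound 4 (0.75 log units; beyond the scatter), resting on the single measured instance a 6.6-fold lower number from compound 1 to compound 2 (0.82 log units; beyond the scatter), with wider bounds because it is carried onto another core. The estimate for compound 4 is 700 nM, between 250 nM and 2000 nM.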

Compound 4, half-maximal inhibitory concentration: 1130 nM
Compound 4: middle estimate off by 1.6-fold (0.21 log units), on the low side; low and high end bracket the measured number.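

In this assay, hydrogen in place of methyl on the saturated chain carbon bound to a bromine atom and a carbonyl carbon gave a 3.5-fold lower number from compound 3 to compound 4 (0.54 log units; beyond the scatter) on the core of compound 3, the same direction as on the core of compound 1, and the two steps agree in size: the same change on two cores in this assay, a 6.6-fold lower number (0.82 log units; beyond the scatter) from compound 1 to compound 2 and a 3.5-fold lower number (0.54 log units; beyond the scatter) from compound 3 to compound 4, 1.9-fold (0.28 log units) apart, within the scatter of two such steps. This rests on two matched pairs, so it supports carrying the change between these two cores only and gives no rule for any other core. It also does not show why the change acts as it does.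

Still open, on these data alone, is how a chlorine atom in place of the chain bromine, or a longer chain than 1-bromoethyl, would read on either core. Also open, as far as these compounds go, is how a carboxylic acid in place of the urea would read.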